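The compounds below may be only part of what the source reports. "The series", "measured", "known", "first", "only" and "open" are said of these compounds alone.

Measured so far in a functional assay on K562 cells (Homo sapiens) for inhibition, read by fluorescence, with a stated time of 72 h; a lower number here means a stronger inhibitor of growth, a higher number a weaker inhibitor of growth:
- compound 1 `COc1ccc(Cn2cnc3c(Nc4cccc(Cl)c4)nc(N[C@H]4CC[C@H](N)CC4)nc32)cc1` gives 2800 nM
- compound 2 `CC(C)CCn1cnc2c(Nc3cccc(O)c3)nc(N[C@H]3CC[C@H](N)CC3)nc21` gives 7600 nM

In this assay compound 1 stands lowest of the two, and its gap to compound 2 lies beyond the scatter. Compound 3 `CC(C)=CCC/C(C)=C/Cn1cnc2c(Nc3cccc(Cl)c3)nc(N[C@H]3CC[C@H](N)CC3)nc21` keeps the core of compound 1 but exchanges 4-methoxybenzyl for 3,7-dimethylocta-2,6-dien-1-yl, a change that reads 2,6-dimethylhepta-1,5-dien-1-yl in place of 4-methoxyphenyl on a saturated chain carbon bound to an aromatic nitrogen when cut one bond further out. Going by the values given here, no measured step shows this change, so no shift beyond the scatter is expected in this assay, and no firm direction. The estimate gives a 1.1-fold higher number from compound 1 to compound 3 (0.03 log units; within the scatter) as the expected step. Compound 3 is expected at 3000 nM within an estimated range of 1000 nM to 9000 nM for now.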

Compound 3, concentration for 50% growth inhibition: 2200 nM
Beside the measured number, compound 3's estimate is 1.4-fold (0.13 log units) above it; the range from low to high includes it.
By their numbers in this assay, from the lowest: compounds 3 and 1 (each within the scatter of the next); then compound 2.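

In this assay the exchange gives a 1.3-fold lower number from compound 1 to compound 3 (0.10 log units; within the scatter) and so leaves the two compounds indistinguishable. On a saturated chain carbon bound to an aromatic nitrogen, 4-methoxyphenyl can therefore give way to 2,6-dimethylhepta-1,5-dien-1-yl, an open carbon chain with no ring, without a shift beyond the scatter in this pair. Nothing available explains why the number holds.

Still open, going by these compounds, is how an amine or a carboxylic acid at this place would read. On these data alone, it is also open whether a fully saturated chain would match the one with double bonds.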